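The source may report more compounds than this note shows. Statements on the series, on what has been measured and on what is new or still open speak of the compounds shown alone.

Among the compounds with values here, compound 2 `CC[C@H](C)[C@H](N)CN(C(=O)[C@@H]1C[C@H]1c1ccc(F)cc1F)c1ccc(-c2ccccc2)cc1` is one of two compounds measured so far in a functional assay for agonist activity at G protein-coupled receptor 88 (Homo sapiens), read by HTRF and cAMP accumulation; a lower number here means that less compound is needed, a higher number that more compound is needed for the effect. In this assay compound 2 gives 1300 nM. Its companion, compound 1 `CC[C@H](C)[C@H](N)CN(C(=O)[C@@H]1C[C@H]1c1cc(F)cc(F)c1)c1ccc(-c2ccccc2)cc1`, differs only in where the two fluorine atoms sit on the aromatic ring attached to the three-membered ring; in this assay compound 1 gives 960 nM. The step of a 1.4-fold higher number from compound 1 to compound 2 (0.13 log units; within the scatter) is the only one available, and it lies within the scatter, so the two compounds cannot be told apart on these numbers.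

Compound 3 `CC[C@H](C)[C@H](N)CN(C(=O)[C@@H]1C[C@H]1c1ccccn1)c1ccc(-c2ccccc2)cc1` carries a different change: pyridin-2-yl in place of 2,4-difluorophenyl on a saturated ring carbon. Within the data shown here, no measured step swaps the whole aromatic group for a ring with a nitrogen atom, so the one step from compound 1 to compound 2 bears on this change only loosely, showing that the shared core tolerates at least a rearrangement of fluorine atoms on that ring without a shift beyond the scatter. For compound 3 the expected step of a 1.5-fold higher number from compound 2 to compound 3 (0.19 log units; within the scatter) is therefore uncertain, and compound 3 is estimated at 2000 nM, with a range from 500 nM to 8000 nM.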

Compound 3, half-maximal effective concentration: 130 nM
For compound 3 the middle estimate is 15-fold (1.19 log units) above the measured one; the whole stated range lies above it.
By their numbers in this assay, from the lowest: compound 3; then compounds 1 and 2 (each within the scatter of the next).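

The group on the three-membered ring proves able to change the result in this assay, which the shift of fluorine atoms between compound 1 and compound 2 did not show. Putting pyridin-2-yl in place of 2,4-difluorophenyl gives a 10-fold lower number from compound 2 to compound 3 (1.00 log units; beyond the scatter), and putting it in place of 3,5-difluorophenyl gives a 7.4-fold lower number from compound 1 to compound 3 (0.87 log units; beyond the scatter), so both fluorinated compounds need clearly more compound for the effect than the pyridine does, whichever way their fluorine atoms are arranged. No measurement is at hand that accounts for this gain.

The change does several things at once: it removes both fluorine atoms, replaces a ring of carbon only with one holding a nitrogen atom, and adds a hydrogen-bond acceptor, and a plain phenyl group would help to separate the loss of fluorine from the arrival of nitrogen. The compounds shown also leave open whether the place of the nitrogen in the ring matters, which pyridin-3-yl and pyridin-4-yl would test, and whether a second ring nitrogen, as in pyrimidin-2-yl, would carry the effect further.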